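A few compounds are considered here, and "the series" means these few. Any claim that something is new, unique, unknown or untested is made for them only; others in the source may bear on it.

Measured compounds:
- compound 2 `CS(=O)(=O)Oc1c(C(=O)NCc2ccc(F)cc2)nc(Br)c2cccnc12` in a functional assay on HCT-116 cells (Homo sapiens) for cytotoxicity, read by MTT assay, with a stated time of 72 h (on this read-out lower numbers stand for stronger inhibition and higher numbers for weaker inhibition), gives > 20000 nM; this is a limit of the assay, not a number
- compound 1 `C[C@@H](CO)Nc1nc(C(=O)NCc2ccc(F)cc2)c(O)c2ncccc12` in this assay gives "not determined" (no result reported)
- compound 3 `C[C@H](CO)Nc1nc(C(=O)NCc2ccc(F)cc2)c(O)c2ncccc12` in this assay gives "not determined" (no result reported)

Where compound 2 stands: it is the only compound of the three with any entry in this assay, and that entry is a limit, so its position on the numbers shown is set by the limit of > 20000 nM in this assay, at which 1 of the 3 values shown sits, alone. Compounds 1 and 3 give nothing to place beside it; they are noted only for (the fact that compounds 1 and 3 differ only in the configuration as drawn). For the measured compounds named here, no step between two measured compounds exists in this set, so no size of step is known from the data themselves.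

Compound 4 `N[C@H]1CC[C@H](Nc2c(C(=O)NCc3ccc(F)cc3)nc(Br)c3cccnc23)CC1` is not yet measured. It differs from compound 2 in one place: (4-aminocyclohexyl)amino in place of (methylsulfonyl)oxy on an aromatic carbon. The (methylsulfonyl)oxy group leaves and the (4-aminocyclohexyl)amino group enters on the same aromatic carbon, ortho to a fused ring and para to the bromo group.

Going by the values given here, with only a limit for compound 2 and no measured step anywhere in the set, the direction and size of the change are expected from the structural change alone. The expectation is for stronger inhibition in this assay, with a step of an at least 4.0-fold lower number from compound 2 to compound 4 (0.60 log units; beyond the scatter) that could well exceed the scatter. Compound 4 is therefore estimated at 5000 nM in this assay, within a range from 500 nM to 40000 nM.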

Compound 4, half-maximal inhibitory concentration: 4000 nM
For compound 4 the middle estimate is 1.3-fold (0.10 log units) above the measured one, within the range that was stated.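

For the compounds shown here, with (4-aminocyclohexyl)amino in place of (methylsulfonyl)oxy on this aromatic carbon, para to a bromo group, the change gives an at least 5.0-fold lower number from compound 2 to compound 4 (0.69 log units; beyond the scatter) in this assay, and this position is now seen to move the read-out, which no earlier compound could show. Compound 2 stands at > 20000 nM, which is a limit of the assay and not a number. Nothing among the data shown accounts for the step, so it stands as an observation on this one pair.

Going by these compounds alone, the one pair cannot separate the contributions of the non-aromatic ring and the terminal amino group: a plain cyclohexylamino group, lacking that amine, or an open aminobutylamino chain at the same aromatic carbon would tell these apart. As far as these compounds go, compounds 1 and 3 have no reported result, so steps involving them cannot be read, and the effect of the configuration as drawn, like that of replacing the bromo group with a chloro group or a methoxy group, remains open.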